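Swapping the sulfonyl substituent: from thiophene to diethylamino

The source may hold more compounds than are shown below. What is called first, only, known or untested is meant among the compounds shown, and "the series" means these compounds.

Measured compounds:
- Compound 1 `CC(C)OC(=O)N1CCC(COc2ccc(N3CCN(S(=O)(=O)C(C)C)CC3)nc2)CC1`: 300 nM
- Compound 2 `CC(C)OC(=O)N1CCC(COc2ccc(N3CCN(S(=O)(=O)c4cccs4)CC3)nc2)CC1`: 1800 nM

Both compounds share one core and differ only in the group attached to the sulfonyl sulfur. In a functional assay on CHO-K1 cells for agonist activity at Glucose-dependent insulinotropic receptor (Homo sapiens), read by a luciferase reporter, with a stated time of 5 h (on this read-out higher numbers stand for an effect only at larger amounts of compound and lower numbers for an effect already at smaller amounts), compound 1 gives 300 nM, while compound 2 gives 1800 nM. Compound 2 therefore stands at the higher of the two numbers, and the step of a 6.0-fold higher number from compound 1 to compound 2 (0.78 log units; beyond the scatter) is beyond the scatter, so compound 2 acts only at larger amounts than compound 1.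

Compound 3 `CCN(CC)S(=O)(=O)N1CCN(c2ccc(OCC3CCN(C(=O)OC(C)C)CC3)cn2)CC1` keeps the core and changes the same position again: diethylamino in place of thiophen-2-yl on a sulfonyl sulfur. For the measured compounds named here, the single measured step that bears on this place is a 6.0-fold higher number from compound 1 to compound 2 (0.78 log units; beyond the scatter), which shows that exchanging a small branched alkyl group for a five-membered aromatic ring moved the number up. Diethylamino, like isopropyl, carries no ring, so the reverse direction is expected: the step of a 3.6-fold lower number from compound 2 to compound 3 (0.56 log units; beyond the scatter) is estimated to bring the number back down toward that of compound 1, though the size is uncertain with only one comparison. Compound 3 is expected to give about 500 nM, within a range of 150 nM to 1800 nM.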

Compound 3, half-maximal effective concentration: 1200 nM
Beside the measured number, compound 3's estimate is 2.4-fold (0.38 log units) below it; low and high end bracket the measured number.
By their numbers in this assay, from the lowest: compound 1; then compounds 3 and 2 (each within the scatter of the next).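

In this assay, the step of a 1.5-fold lower number from compound 2 to compound 3 (0.18 log units; within the scatter) leaves diethylamino and thiophen-2-yl on the sulfonyl sulfur indistinguishable, even though one carries a five-membered aromatic ring and the other carries no ring. Removing the ring is therefore not enough on its own to restore the number of compound 1, as the step of a 4.0-fold higher number from compound 1 to compound 3 (0.60 log units; beyond the scatter) shows: isopropyl remains ahead of diethylamino, and the position tolerates less variation than a simple ring-versus-no-ring split would suggest. Nothing given here explains why isopropyl stands apart from the other two groups.

The three compounds leave open whether the advantage of compound 1 belongs to isopropyl specifically or extends to other compact groups on the sulfur, such as cyclopropyl, tert-butyl or dimethylamino. They also leave open whether any group at this position can bring the number below that of compound 1, and whether a six-membered ring such as phenyl would behave like thiophen-2-yl.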